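The compounds below may be only part of what the source reports. "The series", "measured", "known", "first", "only" and "open" are said of these compounds alone.

Compounds measured in an ADME assay on a cell-free system (plasma, Rattus norvegicus) for metabolic stability, read by LC-MS, with a stated time of 60 min, tested at 100 uM; on this read-out higher numbers stand for a more stable compound and lower numbers for a less stable compound:

compound 1, `Cc1c(OCCCCOc2ccc(C(=O)O)cc2Cl)ccc(C(=O)CC2CCCC2)c1O`, 120%
compound 2, `Cc1c(OCCCCOc2cccc(C(=O)O)c2)ccc(C(=O)CC(C)C)c1C`, 106%
compound 3, `Cc1c(OCCCCOc2cccc(C(=O)O)c2)ccc(C(=O)CC(C)C)c1O`, 100%

Compound 1 stands highest of the three numbers in this assay. Compound 2 is its nearest neighbour, with a number lower by a margin beyond the scatter, and compound 3 is the furthest, lower still and also beyond the scatter. Within the data shown here, the one step between measured compounds that differ in a single place, a number 6 percentage points lower from compound 2 to compound 3 (within the scatter), concerns a hydroxy in place of a methyl on the shared core and falls within the scatter.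

Compound 4, `Cc1c(OCCCCOc2ccc(C(=O)O)c(Cl)c2)ccc(C(=O)CC2CCCC2)c1O`, has not yet been measured in this assay. It differs from compound 1 by 4-carboxy-3-chlorophenyl in place of 4-carboxy-2-chlorophenyl on an oxygen on a saturated carbon. Among the measured compounds shown here, no measured step bears on this change: the step from compound 2 to compound 3 alters the core, not the carboxyphenyl, and no pair among the measured compounds moves a chlorine from one place to another on that ring. With nothing to argue for a shift in either direction, the step of a number 5 percentage points lower from compound 1 to compound 4 (within the scatter) is expected to stay within the scatter. On that basis compound 4 is estimated at 115% in this assay, within a range from 95% to 135%.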

Compound 4, percent of the compound remaining: 97%
Beside the measured number, compound 4's estimate is 18 percentage points above it; the range from low to high includes it.
By their numbers in this assay, from the lowest: compounds 4, 3 and 2 (each within the scatter of the next); then compound 1.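

In this assay, a number 23 percentage points lower from compound 1 to compound 4 (beyond the scatter), showing that the place of the chlorine on the carboxyphenyl ring can matter on its own: the two compounds hold the same atoms, and only 4-carboxy-3-chlorophenyl stands in place of 4-carboxy-2-chlorophenyl on an oxygen on a saturated carbon. The earlier compounds offered a single-place step only on the shared core, and that step stayed within the scatter, so this is the one step among those shown that lies beyond it, and it sits at the carboxyphenyl end of the molecule. Nothing available accounts for the size of this step.

As far as these compounds go, whether the same move of the chlorine would give a similar step with the shorter chain of compound 3 in place of the cyclopentyl group remains open. Also open, from the compounds shown here alone, is what a fluorine or a methyl would do at either place on the ring, and whether a carboxyphenyl with no chlorine on the core of compound 1 would sit nearer compound 1 or compound 4.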